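This account rests on a few compounds, and the source may have more. Where it says the series, first, only, none or still open, it means among the compounds named here.

Of the compounds shown here, three built on a shared core have been tested in an assay on membranes from HeLa cells for displacement of a labelled ligand from adenosine receptor A3 (Homo sapiens), read by scintillation counting, with a stated time of 180 min, tested at 1 uM; a lower number here means less inhibition, a higher number more inhibition at the concentration tested (going by the name of the read-out). Compound 1 `CCCC(=O)C1=C(C)NC(=O)NC1c1ccsc1` carries a propyl group on its carbonyl carbon, and in this assay compound 1 gives 1%. Compound 2 `CCNC(=O)C1=C(C)NC(=O)NC1c1ccsc1` gives 1%, and the step of no change at the digits printed from compound 1 to compound 2 (within the scatter), ethylamino in place of propyl on a carbonyl carbon, therefore changes nothing that the scatter would not explain. Compound 3 `CCC(CC)OC(=O)C1=C(C)NC(=O)NC1c1ccoc1` bears a furan-3-yl group where compounds 1 and 2 bear thiophen-3-yl, and in this assay compound 3 gives 5%, a number within the scatter of both other values, so the three compounds cannot be told apart on these figures. Compound 4 `CCC(CC)OC(=O)C1=C(C)NC(=O)NC1c1ccsc1` has not yet been measured. It differs from compound 3 in one place: thiophen-3-yl in place of furan-3-yl on a saturated ring carbon. For the measured compounds named here, no measured step covers this exchange; the only step available, no change at the digits printed from compound 1 to compound 2 (within the scatter), concerns the carbonyl substituent and not the ring. Still, compounds 1 and 2, which carry thiophen-3-yl, and compound 3, which carries furan-3-yl, all give low numbers, so no step beyond the scatter is expected. The expected step is a number 2 percentage points lower from compound 3 to compound 4 (within the scatter), and compound 4 is estimated at 3%, between 0% and 12%.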

Compound 4, a percentage reported as inhibition, at one concentration (the size of the read-out at that concentration, not a potency): 6%
Estimate against measurement, compound 4: 3 percentage points below; low and high end bracket the measured number.
By their numbers in this assay, from the lowest: compounds 1, 2, 3 and 4 (each within the scatter of the next).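

Thiophen-3-yl in place of furan-3-yl on the saturated ring carbon gives a number 1 percentage points higher from compound 3 to compound 4 (within the scatter) in this assay, so the two rings cannot be told apart at this position in this assay. With thiophen-3-yl held fixed, the carbonyl substituent can also be compared: (pentan-3-yl)oxy in place of ethylamino gives a number 5 percentage points higher from compound 2 to compound 4 (within the scatter) and (pentan-3-yl)oxy in place of propyl gives a number 5 percentage points higher from compound 1 to compound 4 (within the scatter), so neither exchange separates these compounds. No further evidence is available to bear on these results.

As far as these compounds go, all four compounds carry a five-membered aromatic ring on the saturated ring carbon, so it remains open how a phenyl ring there would behave. From the compounds shown here alone, it also remains open whether a longer chain or a carboxylic acid at the carbonyl carbon would give a step beyond the scatter.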